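The source may hold more compounds than are shown below. What is called first, only, known or untested is meant among the compounds shown, and "the series" means these compounds.

Measured in a functional assay on the whole organism with Rattus norvegicus as the target; on this read-out lower numbers stand for an effect already at smaller amounts and higher numbers for an effect only at larger amounts of compound:
- compound 1 `COc1cc(N)c(Cl)cc1C(=O)NCCN(C)Cc1ccccc1C`: 2 mg/kg
- compound 2 `COc1cc(N(C)C)c(Cl)cc1C(=O)NC1CCN(Cc2ccccc2)C1`: 0.12 mg/kg
- compound 3 `COc1cc(N(C)C)c(Cl)cc1C(=O)NC1CCN(C2CCCCC2)C1`: 1 mg/kg

Of these three, compound 2 has the lowest number, and its gaps to the other two lie beyond the scatter. Compound 4 `COc1cc(NC(C)=O)c(Cl)cc1C(=O)NC1CCN(Cc2ccccc2)C1` differs from compound 2 by acetamido in place of dimethylamino on an aromatic carbon, with acetamido in place of dimethylamino on an aromatic carbon. For the measured compounds named here, no measured step covers this change. Going by the values given here, the only measured step, an 8.3-fold higher number from compound 2 to compound 3 (0.92 log units; beyond the scatter), is modest and concerns a different place, with cyclohexyl in place of benzyl on an amine nitrogen in a ring. Using it only as a guide to size, a similar move towards a higher number is expected in this assay, though the direction remains uncertain. The expected change is a 5.0-fold higher number from compound 2 to compound 4 (0.70 log units; beyond the scatter). For compound 4 the estimated value is 0.6 mg/kg, within an expected range of 0.15 mg/kg to 3 mg/kg.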

Compound 4, dose for half-maximal effect: 1.8 mg/kg
Compound 4: the middle estimate sits 3.0-fold (0.48 log units) below what was measured; the range from low to high includes it.
By their numbers in this assay, from the lowest: compound 2; then compounds 3, 4 and 1 (each within the scatter of the next).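

This position, para to a large group and ortho to a chloro group, turns out to matter in this assay: acetamido in place of dimethylamino gives a 15-fold higher number from compound 2 to compound 4 (1.18 log units; beyond the scatter), a large step. For the compounds shown here, until now the only measured step lay on the amine nitrogen in a ring, so this is the first sign that the aromatic carbon also affects the dose. Nothing available explains the step.

On these data alone, it remains open how methylamino or the longer propionamido would read at this place. Whether the step carries over to the cyclohexyl series of compound 3 is also unsettled.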